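The source may hold more compounds than are shown below. What is called first, only, known or untested is meant among the compounds shown, and "the series" means these compounds.

Of the compounds shown here, three sharing one core have been measured in an ADME assay on MT4 cells (Homo sapiens) for cytotoxicity; a lower number here means that less compound is tolerated, a higher number that more compound is tolerated. Compound 1 (`Cc1cc(C)cc(Cn2c(SCC(=O)Nc3ccccc3[N+](=O)[O-])nc3ccc(Cl)cc32)c1`) gives 131000 nM. Compound 2 (`Cc1cc(C)cc(S(=O)(=O)n2c(SCC(=O)Nc3ccccc3[N+](=O)[O-])nc3ccc(Cl)cc32)c1`) gives > 235000 nM, which is a limit of this assay and not a number. Compound 3 (`Cc1cc(C)cc(Cn2c(SCC(=O)Nc3ccc(C)cc3Cl)nc3ccc(Cl)cc32)c1`) gives 79300 nM. For the measured compounds named here, only one other number is available for comparison, and it lies within the scatter of compound 3: a 1.7-fold lower number from compound 1 to compound 3 (0.22 log units; within the scatter).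

Compound 4 (`Cc1cc(C)cc(S(=O)(=O)n2c(SCC(=O)Nc3ccc(C)cc3Cl)nc3ccc(Cl)cc32)c1`) has not yet been measured. It differs from compound 3 by having (3,5-dimethylphenyl)sulfonyl in place of 3,5-dimethylbenzyl on an aromatic nitrogen. The same exchange has been measured once, with the 2-nitrophenyl amide rather than the 2-chloro-4-methylphenyl amide: an at least 1.7-fold higher number from compound 1 to compound 2 (0.25 log units; that floor lies within the scatter). For compound 2, that step ends at a limit: the limit of > 235000 nM in this assay, at which 1 of the 3 values shown sits. This single step therefore suggests a direction but does not fix a size, and its floor does not clear the scatter.

A modest rise in the number is expected in this assay, possibly none beyond the scatter. For compound 4 the estimated value is 125000 nM, with an expected range from 55000 nM to 235000 nM. The expected change is a 1.6-fold higher number from compound 3 to compound 4 (0.20 log units; within the scatter).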

Compound 4, half-maximal cytotoxic concentration: > 234000 nM
Compound 4 gave a limit, no number (the forecaster's own chance of this, stated with the estimate: 35%); at least 1.8-fold (0.27 log units) between middle value and limit.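

In this assay, putting (3,5-dimethylphenyl)sulfonyl in place of 3,5-dimethylbenzyl on the aromatic nitrogen now gives a step that clears the scatter: an at least 2.9-fold higher number from compound 3 to compound 4 (0.46 log units; beyond the scatter). The earlier step at this position had only a floor within the scatter, so the direction it hinted at now has support from a second amide, and both pairs shown point the same way: the same change on two cores in this assay, an at least 1.7-fold higher number (0.25 log units; that floor lies within the scatter) from compound 1 to compound 2 and an at least 2.9-fold higher number (0.46 log units; beyond the scatter) from compound 3 to compound 4; the limit leaves it open whether they differ. Compound 4 gives > 234000 nM, which is a limit of the assay and not a number, so the new step fixes only a floor for the change and not its size.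

Because both sulfonyl compounds end at limits, the step between them cannot be read, and the compounds shown do not tell whether the amide group matters once the sulfonyl group is in place: the limit of > 234000 nM in this assay, at which 1 of the 4 values shown sits. Also open, on these data alone, is how a benzoyl group on that aromatic nitrogen, or an amine on the aromatic ring of the sulfonyl group, would behave in this assay.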